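Swapping the amine end: what compound 3 may show

The compounds below may be only part of what the source reports. "The series", "measured", "known", "first", "only" and "open" are said of these compounds alone.

Compound 1 `CCN(C)CCCOc1ccc2cc(NC(=O)c3ccc(O)c(CC=C(C)C)c3)c(=O)oc2c1C` gives 730 nM
Compound 2 `CC(C)=CCc1cc(C(=O)Nc2cc3ccc(OCCCN(C)C(C)(C)C)c(C)c3oc2=O)ccc1O` gives 880 nM

In a functional assay on SK-BR-3 cells (Homo sapiens) for antiproliferative activity (on this read-out higher numbers stand for weaker inhibition and lower numbers for stronger inhibition), compound 2 gives 880 nM and so sits level with compound 1, within the usual scatter. The next compound, compound 3 `COC(=O)CNCCCOc1ccc2cc(NC(=O)c3ccc(O)c(CC=C(C)C)c3)c(=O)oc2c1C`, keeps the shared core and changes only the amine end of the chain (((methoxycarbonyl)methyl)amino in place of methyl(tert-butyl)amino on a saturated chain carbon, three bonds along the chain from an oxygen on an aromatic ring). Here ((methoxycarbonyl)methyl)amino stands in place of methyl(tert-butyl)amino on a saturated chain carbon, three bonds along the chain from an oxygen on an aromatic ring.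

For the measured compounds named here, only one measured step bears on this, since it also changes a group on that amine nitrogen (a 1.2-fold higher number from compound 1 to compound 2 (0.08 log units; within the scatter)). It stayed within the scatter, but it is a single step, and neither measured compound carries a methoxycarbonyl group. No clear shift is therefore expected in this assay, and the estimated step is a 1.0-fold lower number from compound 2 to compound 3 (0.02 log units; within the scatter) in size. Compound 3 is expected near 850 nM with an estimated range from 330 nM to 2300 nM around it.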

Compound 3, half-maximal inhibitory concentration: 1060 nM
Compound 3: middle estimate off by 1.2-fold (0.10 log units), on the low side, and the stated range covers the measured number.
By their numbers in this assay, from the lowest: compounds 1, 2 and 3 (each within the scatter of the next).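

In this assay, putting ((methoxycarbonyl)methyl)amino in place of methyl(tert-butyl)amino gives a 1.2-fold higher number from compound 2 to compound 3 (0.08 log units; within the scatter) and putting it in place of ethyl(methyl)amino gives a 1.5-fold higher number from compound 1 to compound 3 (0.16 log units; within the scatter) so neither change moves the number beyond the scatter. The earlier compounds shown here varied only simple carbon groups on the amine nitrogen, whereas compound 3 shows that this position, on a saturated chain carbon, three bonds along the chain from an oxygen on an aromatic ring, also accepts an end with a methoxycarbonyl group and a hydrogen-bond donor with no clear shift. No available evidence explains why the number holds steady across these amine ends.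

Going by these compounds, it remains open whether a carboxylic acid in place of the methoxycarbonyl group would also leave the number within the scatter. The same question stands for a ring amine such as morpholine at the chain end, or for a longer chain.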